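Benzyl ether to diaryl ether: compound 3 to compound 4

The source may report more compounds than this note shows. Statements on the series, on what has been measured and on what is new or still open speak of the compounds shown alone.

In a functional assay on cells for agonist activity at Free fatty acid receptor 1 (Mus musculus), read by FLIPR and calcium flux, with a stated time of 100 s (on this read-out lower numbers stand for an effect already at smaller amounts and higher numbers for an effect only at larger amounts of compound), compound 1 `O=C(O)C1CC(=O)N(c2ccc(OCc3ccc(Cl)cc3Cl)cc2)C1` gives > 33000 nM. In this assay compound 2 `O=C(O)C[C@@H]1CCCN1c1ccc(OCc2ccc(Cl)cc2Cl)cc1` gives 4500 nM. In this assay compound 3 `Cc1ccccc1COc1ccc(N2CCC[C@H]2CC(=O)O)cc1` gives 3400 nM.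

The value of compound 1 is a limit of this assay and not a number: the limit of > 33000 nM in this assay, at which 1 of the 3 values shown sits. Within the data shown here, compound 3 and compound 2 are the only numbers, and they lie within the scatter of each other: a 1.3-fold lower number from compound 2 to compound 3 (0.12 log units; within the scatter). Compound 4 `Cc1ccc(Oc2ccc(N3CCC[C@H]3CC(=O)O)cc2)cc1` differs from compound 3 by 4-methylphenyl in place of 2-methylbenzyl on an oxygen on an aromatic ring. The one measured step exchanged the aryl group on the saturated chain carbon and left the number within the scatter; no measured step removes that carbon, so nothing shown bears directly on this change. A moderate rise is nevertheless expected, a 2.4-fold higher number from compound 3 to compound 4 (0.37 log units; beyond the scatter). For compound 4 the estimate is 8000 nM, range 2500 nM to 25000 nM.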

Compound 4, half-maximal effective concentration: > 33000 nM
Compound 4 ended at the assay's limit; the forecaster's own chance of this, stated with the estimate: 20%; middle value at least 4.1-fold (0.61 log units) from the limit.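

On the oxygen on an aromatic ring, 4-methylphenyl in place of 2-methylbenzyl gives a step beyond the scatter in this assay: an at least 9.7-fold higher number from compound 3 to compound 4 (0.98 log units; beyond the scatter). The aryl exchange on the saturated chain carbon had left the number within the scatter, so this is the first change at this end of the series shown to cost activity among compounds that differ in one place. The result for compound 4 is a limit and not a number: the limit of > 33000 nM in this assay, at which 2 of the 4 values shown sit.

On these data alone, the change drops the chain carbon and alters the aryl group together, so the share of each stays open. 2-Methylphenyl or 4-methylbenzyl on that oxygen would separate the two.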